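Amide Aryl Swap on a Cyclopropane-Dicarboxamide Kinase Inhibitor Scaffold

A few compounds are considered here, and "the series" means these few. Any claim that something is new, unique, unknown or untested is made for them only; others in the source may bear on it.

Measured compounds:
compound 1, `Cc1cccc(NC(=O)C2(C(=O)Nc3ccc(Nc4ncc(F)c(-c5cc(F)c6nc(C)n(C(C)C)c6c5)n4)cc3)CC2)c1`, 179 nM
compound 2, `Cc1nc2c(F)cc(-c3nc(Nc4ccc(CNC(=O)C5(C(=O)Nc6ccc(Br)cc6)CC5)cc4)ncc3F)cc2n1C(C)C`, 330 nM

Of the compounds shown here, two sharing the same fluorinated pyrimidine core have been tested in a functional assay on HeLa cells (Homo sapiens) for antiproliferative activity, read by CCK-8 assay, with a stated time of 72 h; a lower number here means a stronger inhibitor, a higher number a weaker inhibitor. In this assay compound 1 gives 179 nM, and compound 2 gives 330 nM. The two values lie within the usual scatter of each other, so compound 1 cannot be set apart from compound 2 on these numbers alone; it simply stands among two closely spaced results.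

Compound 3, `Cc1nc2c(F)cc(-c3nc(Nc4ccc(NC(=O)C5(C(=O)Nc6ccc(F)cc6)CC5)cc4)ncc3F)cc2n1C(C)C`, has not yet been measured. It differs from compound 1 in one place: 4-fluorophenyl in place of 3-methylphenyl on an amide-type nitrogen. The change keeps the same count of heavy atoms, the same ring type and no donors or acceptors either way. Among the measured compounds shown here, with no measured pair showing what such a swap does on this core, the step is expected to be small, in no clear direction, and within the scatter. Compound 3 is therefore expected to give 200 nM, with a plausible range from 90 nM to 450 nM, which corresponds to an estimated step of a 1.1-fold higher number from compound 1 to compound 3 (0.05 log units; within the scatter).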

Compound 3, half-maximal inhibitory concentration: 191 nM
For compound 3 the middle estimate is 1.0-fold (0.02 log units) above the measured one; measured number inside the range.
By their numbers in this assay, from the lowest: compounds 1, 3 and 2 (each within the scatter of the next).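

In this assay, 4-fluorophenyl in place of 3-methylphenyl on an amide-type nitrogen gives a 1.1-fold higher number from compound 1 to compound 3 (0.03 log units; within the scatter), which lies within the scatter. Among the compounds shown here, this is the only one-place comparison available on the shared core, and it shows that these two aryl groups cannot be told apart at this position in this read-out. The data offer no measured basis for interpreting this result.

The compounds shown leave open whether a group of a different kind at this position, such as one carrying an amine or a carboxylic acid, would also stay within the scatter of compound 1 in this assay. Compound 2 differs from compound 3 in more than one place, so what each of its changes does alone remains unread.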